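The source may hold more compounds than are shown below. What is called first, only, known or untested is meant among the compounds shown, and "the series" means these compounds.

Measured so far in a functional assay on HCT-116 cells (Homo sapiens) for cytotoxicity, read by sulforhodamine B assay, with a stated time of 48 h; on this read-out higher numbers stand for weaker inhibition and lower numbers for stronger inhibition
compound 1 `CCCCNC(=O)N1Cc2c(NC(=O)c3ccc(F)cc3)nn(C(=O)c3ccccc3)c2C1` gives 30800 nM
compound 2 `CC(=O)n1nc(NC(=O)c2ccccc2)c2c1CN(C(=O)c1ccccc1)C2` gives 580 nM
compound 3 `CC(=O)n1nc(NC(=O)c2ccccc2)c2c1CN(C(=O)C1CCC(C)CC1)C2` gives 12200 nM

In this assay compound 3 at 12200 nM stands second highest of the three numbers. Compound 1 at 30800 nM reads higher, and compound 2 at 580 nM reads lower.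

The next compound is compound 4 `CC(=O)n1nc(NC(=O)c2ccccc2)c2c1CN(C(=O)c1cccc([N+](=O)[O-])c1)C2` with the change 3-nitrophenyl in place of 4-methylcyclohexyl on a carbonyl carbon in which 3-nitrophenyl stands in place of 4-methylcyclohexyl on a carbonyl carbon, the other neighbour being an amide-type nitrogen in a ring.

For the measured compounds named here, one measured step bears on this: a 21-fold higher number from compound 2 to compound 3 (1.32 log units; beyond the scatter) for 4-methylcyclohexyl in place of phenyl on a carbonyl carbon, a large step beyond the scatter. Compound 4 restores an aromatic ring at that place, so a step towards a lower number is expected, opposite in direction to that one. Going by the values given here, no measured compound carries 3-nitrophenyl, so the size of the step is uncertain. Compound 2 at 580 nM serves as the nearest reference, and a full return to that value is not assumed.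

The estimate is a 10-fold lower number from compound 3 to compound 4 (1.01 log units; beyond the scatter) as the expected step. For compound 4 the estimated value is 1200 nM with an expected range from 300 nM to 6000 nM in this assay.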

Compound 4, half-maximal inhibitory concentration: 17300 nM
Compound 4: middle estimate off by 14-fold (1.16 log units), on the low side; the whole stated range lies below it.
By their numbers in this assay, from the lowest: compound 2; then compounds 3, 4 and 1 (each within the scatter of the next, the first and the last beyond it).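

In this assay, the step of a 1.4-fold higher number from compound 3 to compound 4 (0.15 log units; within the scatter) shows that an aromatic ring on this carbonyl carbon does not by itself restore the low number of compound 2, as 3-nitrophenyl and 4-methylcyclohexyl cannot be told apart here. The step of a 30-fold higher number from compound 2 to compound 4 (1.47 log units; beyond the scatter) shows that a single nitro in place of hydrogen on an aromatic carbon is enough to lose what the unsubstituted phenyl gives, so among these compounds the low number belongs to phenyl alone and not to aromatic rings at this place in general. No measurement at hand bears on what lies behind this result.

Open, on these data alone, is whether other groups on that phenyl ring, such as an amine, a methoxy group or a carboxylic acid, would stay close to compound 2 or read like compound 4, and whether a nitro group on a different ring carbon would read the same. Also open, as far as these compounds go, is how a cyclohexyl ring without its methyl or a short alkyl chain would read on this carbonyl carbon.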